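The compounds below may be only part of what the source reports. "The series", "measured", "known", "first", "only" and "open" are said of these compounds alone.

Compound 1 `CS(=O)(=O)N1CCC2(CC1)OOC1(CCCC1)OO2`: > 100 ug/mL
Compound 2 `CCS(=O)(=O)N1CCC2(CC1)OOC1(CCCCCC1)OO2`: > 100 ug/mL

In a functional assay on Huh-7 cells (Homo sapiens) for cytotoxicity, read by MTT assay, with a stated time of 72 h (a lower number here means that less compound is tolerated, a higher number that more compound is tolerated), compound 2 gives > 100 ug/mL as its result, which is a limit of the assay and not a number. All the results offer so far is the limit of > 100 ug/mL in this assay, at which 2 of the 2 values shown sit, and no exact value. Compound 3 `O=S(=O)(Cc1ccccc1)N1CCC2(CC1)OOC1(CCCCCC1)OO2` differs from compound 2 by the change phenyl in place of methyl on a saturated chain carbon bound to a sulfonyl sulfur that puts phenyl in place of methyl on a saturated chain carbon bound to a sulfonyl sulfur. Within the data shown here, no measured step shows what such a change does, so only a modest shift is expected in this assay, towards less compound tolerated if any: the estimated step is an at least 1.1-fold lower number from compound 2 to compound 3 (0.04 log units; that floor lies within the scatter) and may stay within the scatter. For compound 3 the estimated value is 90 ug/mL with an expected range from 35 ug/mL to 150 ug/mL overall.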

Compound 3, half-maximal cytotoxic concentration: > 100 ug/mL
Compound 3: a limit, no number (the forecaster's own chance of this, stated with the estimate: 60%); middle value at least 1.1-fold (0.04 log units) from the limit.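

Compound 2 and compound 3 each give only a limit and not a number, so no step between them can be read: the limit of > 100 ug/mL in this assay, at which 3 of the 3 values shown sit.

On these data alone, whether phenyl in place of methyl changes the result at all in this assay stays open.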